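The source may hold more compounds than are shown below. What is called first, only, known or untested is meant among the compounds shown, and "the series" means these compounds.

Compound 1 `CCCCN(C)c1cc(C(C)(C)C)ccc1CNC(=O)C(C)c1ccc(NS(C)(=O)=O)c(F)c1`: 1 nM
Compound 2 `CC(C)COc1cc(C(C)(C)C)ccc1CNC(=O)C(C)c1ccc(NS(C)(=O)=O)c(F)c1`: 2.1 nM

Among the measured compounds shown here, in an assay on cells for antagonist activity at transient receptor potential cation channel subfamily V member 1 (Homo sapiens), read by FLIPR and calcium flux, with a stated time of 6 min (a lower number here means a stronger inhibitor, a higher number a weaker inhibitor), compound 2 gives 2.1 nM, the higher of the two numbers measured so far; the single measured step, a 2.1-fold higher number from compound 1 to compound 2 (0.32 log units; beyond the scatter), separates it from compound 1, which gives 1 nM. Compound 3 `CCCCSc1cc(C(C)(C)C)ccc1CNC(=O)C(C)c1ccc(NS(C)(=O)=O)c(F)c1` has not yet been measured. It differs from compound 2 in one place: butylsulfanyl in place of isobutoxy on an aromatic carbon. For the measured compounds named here, the only measured step that bears on this change is the one from compound 1 to compound 2, which also exchanged the group on that aromatic carbon and was modest in size. Going by the values given here, no measured pair trades isobutoxy for butylsulfanyl, so the direction is open; given that the one comparable exchange moved the number only modestly, a step of similar size in either direction in this assay, or none beyond the scatter, is expected. The estimate for compound 3 is therefore 2.2 nM, with a range from 0.7 nM to 7 nM. That estimate means an expected step of a 1.0-fold higher number from compound 2 to compound 3 (0.02 log units; within the scatter).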

Compound 3, inhibition constant: 6.7 nM
Compound 3: the middle estimate sits 3.0-fold (0.48 log units) below what was measured; measured number inside the range.
By their numbers in this assay, from the lowest: compound 1; then compound 2; then compound 3.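

At this aromatic carbon, ortho to a large group and meta to a tert-butyl group, a second exchange in this assay gives a 3.2-fold higher number from compound 2 to compound 3 (0.50 log units; beyond the scatter) and shows that butylsulfanyl and isobutoxy, with the same count of heavy atoms, are not interchangeable here. Against butyl(methyl)amino, butylsulfanyl gives a 6.7-fold higher number from compound 1 to compound 3 (0.83 log units; beyond the scatter) and this widens the span produced by changing this one group while the rest of the molecule stays fixed. Nothing given here accounts for this order.

The step from isobutoxy to butylsulfanyl changes both the atom joined to the ring and the shape of the chain, so a straight butoxy group would be needed to separate the two changes. Going by these compounds, how an isobutylsulfanyl group, a shorter chain such as ethylsulfanyl, or a cyclic amine such as pyrrolidine would read at this carbon stays open.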